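From 3-fluorobenzyl to 4-fluorobenzyl on the shared core

The source may hold more compounds than are shown below. What is called first, only, known or untested is meant among the compounds shown, and "the series" means these compounds.

In a functional assay on MNK45 cells (Homo sapiens) for inhibition, read by MTT assay, with a stated time of 48 h (on this read-out lower numbers stand for stronger inhibition and higher numbers for weaker inhibition), compound 1 `Cc1ccc(NC(=O)NC(=O)c2ccc(OCc3ccc(C(F)(F)F)cc3)cc2)cc1-c1nc2ccccc2[nH]1` gives 16800 nM, while compound 2 `Cc1ccc(NC(=O)NC(=O)c2ccc(OCc3cccc(F)c3)cc2)cc1-c1nc2ccccc2[nH]1` gives 53000 nM, the higher of the two numbers. Compound 3 `Cc1ccc(NC(=O)NC(=O)c2ccc(OCc3ccc(F)cc3)cc2)cc1-c1nc2ccccc2[nH]1` departs from compound 2 through (4-fluorophenyl in place of 3-fluorophenyl on a saturated chain carbon bound to an oxygen on an aromatic ring). Among the measured compounds shown here, only one measured step bears on this change: a 3.2-fold higher number from compound 1 to compound 2 (0.50 log units; beyond the scatter). It is modest and replaces 4-(trifluoromethyl)phenyl with 3-fluorophenyl, so it tells only indirectly about 4-fluorophenyl. An estimated step of a 1.6-fold lower number from compound 2 to compound 3 (0.21 log units; within the scatter) is expected, smaller than the measured one and toward a lower number. For compound 3 the expected value is 33000 nM, with an estimated range of 14000 nM to 75000 nM.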

Compound 3, half-maximal inhibitory concentration: 240 nM
Estimate against measurement, compound 3: 140-fold (2.14 log units) above; the measured number lies below the stated range.
By their numbers in this assay, from the lowest: compound 3; then compound 1; then compound 2.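

In this assay, among the compounds shown here, the exchange of 3-fluorobenzyl for 4-fluorobenzyl, with the same atoms joined differently, gives a 220-fold lower number from compound 2 to compound 3 (2.34 log units; beyond the scatter) and is far larger than the only earlier step. Fluoro in place of trifluoromethyl on an aromatic carbon gives a 70-fold lower number from compound 1 to compound 3 (1.85 log units; beyond the scatter) as well, so compound 3 is the strongest of the three, and both the place of the fluoro and the identity of the group count here.

From the compounds shown here alone, whether a chloro or methoxy group in place of that fluoro, or a longer chain in place of the benzyl carbon, would hold this low number remains open. What lies behind so sharp a difference is also open, as no measurement at hand speaks to it.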